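Series notes: hydrogen for methyl on an aromatic nitrogen

A few compounds are considered here, and "the series" means these few. Any claim that something is new, unique, unknown or untested is made for them only; others in the source may bear on it.

Compound 2 `Cn1cc([N+](=O)[O-])cc1-c1nnc(-c2ccccc2Br)o1` serves as the reference; in an ADME assay on Vero cells (Chlorocebus sabaeus) for cytotoxicity, read by MTT assay, with a stated time of 72 h (on this read-out lower numbers stand for stronger inhibition and higher numbers for weaker inhibition), compound 2 gives 303000 nM. Compound 1 `O=[N+]([O-])c1c[nH]c(-c2nnc(-c3ccccc3Br)o2)c1` differs from compound 2 by hydrogen in place of methyl on an aromatic nitrogen and in this assay compound 1 gives 190000 nM, the step being a 1.6-fold lower number from compound 2 to compound 1 (0.20 log units; within the scatter). Compound 3 `Cn1cc([N+](=O)[O-])cc1-c1nnc(-c2ccc[nH]2)o1` carries a different core, differing from compound 2 by 1H-pyrrol-2-yl in place of 2-bromophenyl on an aromatic carbon; in this assay compound 3 gives 208000 nM, the step being a 1.5-fold lower number from compound 2 to compound 3 (0.16 log units; within the scatter). The values of compound 1 and compound 3 lie within the scatter of each other, so no order between them is claimed.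

Compound 4 `O=[N+]([O-])c1c[nH]c(-c2nnc(-c3ccc[nH]3)o2)c1` has not yet been measured. It differs from compound 3 by hydrogen in place of methyl on an aromatic nitrogen, the same change as from compound 2 to compound 1, made on the core of compound 3 instead of the core of compound 2. Since that earlier change moved the number only by a 1.6-fold lower number from compound 2 to compound 1 (0.20 log units; within the scatter), a small shift is expected in this assay: the step from compound 3 to compound 4 is estimated at a 1.4-fold lower number from compound 3 to compound 4 (0.14 log units; within the scatter). Compound 4 is therefore expected to give about 150000 nM, most likely between 80000 nM and 300000 nM.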

Compound 4, half-maximal inhibitory concentration: 227000 nM
The estimate for compound 4 lay 1.5-fold (0.18 log units) below the measured number; the range from low to high includes it.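

In this assay, hydrogen in place of methyl on the aromatic nitrogen gives a 1.1-fold higher number from compound 3 to compound 4 (0.04 log units; within the scatter), so no shift can be read on the core of compound 3. Set beside the earlier step, the change shows no detectable difference between the two cores: the same change on two cores in this assay, a 1.6-fold lower number (0.20 log units; within the scatter) from compound 2 to compound 1 and a 1.1-fold higher number (0.04 log units; within the scatter) from compound 3 to compound 4, 1.7-fold (0.24 log units) apart, within the scatter of two such steps. This does not show that the change is without effect on either core or that the two cores respond identically: both steps and the gap between them stay within the scatter, and two cores support no general rule for the series.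

The compounds shown leave open how the read-out behaves with a group larger than methyl on that nitrogen, such as ethyl or a longer chain, or with an amine or a carboxylic acid in place of the nitro group. Whether any change in this series can produce a step beyond the scatter in this assay also stays open, as every step shown lies within it.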